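The source may report more compounds than this note shows. Statements on the series, on what has been measured and on what is new or still open speak of the compounds shown alone.

Measured compounds:
- compound 1 `CCCn1c(=O)[nH]c2nc(-c3ccc(S(=O)(=O)N4CCN(c5ccc(F)cc5)CC4)cc3)[nH]c2c1=O`; in an assay on CHO cells for displacement of a labelled ligand from adenosine receptor A1 (Homo sapiens), read by scintillation counting, with a stated time of 90 min, in the presence of a further agent that is not named here (a lower number here means a stronger inhibitor, a higher number a weaker inhibitor), compound 1 gives > 1000 nM, a limit of the assay.
- compound 2 `CCCn1c(=O)[nH]c2nc(-c3ccc(S(=O)(=O)N4CCN(Cc5ccc(Br)c(F)c5)CC4)cc3)[nH]c2c1=O`; in this assay compound 2 gives 326 nM.

Going by the values given here, compound 2 carries the only number measured so far; the other value is a limit (the limit of > 1000 nM in this assay, at which 1 of the 2 values shown sits). Among the compounds with values here, the single measured step, an at least 3.0-fold lower number from compound 1 to compound 2 (0.48 log units; beyond the scatter), changes the group on the amine nitrogen in a ring and does not touch the fluoro. Compound 3 `CCCn1c(=O)[nH]c2nc(-c3ccc(S(=O)(=O)N4CCN(Cc5ccc(Br)cc5)CC4)cc3)[nH]c2c1=O` differs from compound 2 by hydrogen in place of fluoro on an aromatic carbon. Within the data shown here, no measured step covers this change, so the expectation is a 1.1-fold higher number from compound 2 to compound 3 (0.03 log units; within the scatter), a step not beyond the scatter. Compound 3 is therefore estimated at 350 nM, within 120 nM to 1000 nM.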

Compound 3, inhibition constant: > 1000 nM
Compound 3 ended at the assay's limit; the forecaster's own chance of this, stated with the estimate: 20%; middle value at least 2.8-fold (0.45 log units) from the limit.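

In this assay, hydrogen in place of fluoro on the aromatic carbon ortho to the bromo group gives an at least 3.0-fold higher number from compound 2 to compound 3 (0.48 log units; beyond the scatter), so the 4-bromobenzyl group without the fluoro does not hold the number of compound 2. Compound 3 gives > 1000 nM, which is a limit, and this limit recurs across the series: the limit of > 1000 nM in this assay, at which 2 of the 3 values shown sit. The step from compound 1 to compound 3 cannot be read.

Open, as far as these compounds go, is whether a chloro or a methoxy group on this carbon would hold the number of compound 2. Also open, from the compounds shown here alone, is how far compound 3 lies past its limit.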